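From 2-hydroxyphenyl to 4-hydroxyphenyl in a trifluoromethoxy series

The compounds below may be only part of what the source reports. "The series", "measured", "known", "first", "only" and "open" are said of these compounds alone.

Compound 1 `Oc1ccc(-c2cc(-c3ccc(F)cc3)cc(-c3ccc(O)cc3)n2)cc1` in a functional assay on DU-145 cells (Homo sapiens) for inhibition (on this read-out higher numbers stand for weaker inhibition and lower numbers for stronger inhibition), gives 6030 nM. Compound 2 `Oc1ccc(-c2cc(-c3ccc(OC(F)(F)F)cc3)cc(-c3ccccc3O)n2)cc1` in this assay reaches only > 50000 nM, which is a limit of the assay and not a number, as shown by the limit of > 50000 nM in this assay, at which 1 of the 2 values shown sits. Compound 3 `Oc1ccc(-c2cc(-c3ccc(OC(F)(F)F)cc3)cc(-c3ccc(O)cc3)n2)cc1` differs from compound 2 by 4-hydroxyphenyl in place of 2-hydroxyphenyl on an aromatic carbon, so compound 3 carries the same pair of 4-hydroxyphenyl groups as compound 1. The step is expected to be an at least 6.2-fold lower number from compound 2 to compound 3 (0.79 log units; beyond the scatter), toward stronger inhibition, the direction in which the values of compound 1 and compound 2 point. The value expected for compound 3 is 8000 nM, with a range from 2000 nM to 40000 nM.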

Compound 3, half-maximal inhibitory concentration: 5390 nM
Estimate against measurement, compound 3: 1.5-fold (0.17 log units) above; low and high end bracket the measured number.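

In this assay, 4-hydroxyphenyl in place of 2-hydroxyphenyl next to the ring nitrogen gives an at least 9.2-fold lower number from compound 2 to compound 3 (0.96 log units; beyond the scatter), so the place of the hydroxyl on this phenyl group matters in this series. The value of compound 2 is a limit of the assay and not a number: the limit of > 50000 nM in this assay, at which 1 of the 3 values shown sits. With the 4-hydroxyphenyl pair kept, trifluoromethoxy in place of fluoro gives a 1.1-fold lower number from compound 1 to compound 3 (0.05 log units; within the scatter), so this exchange does not separate the two compounds.

Open, as far as these compounds go, is how an amine or a carboxylic acid in place of the hydroxyl on this phenyl group would read in this assay.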